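A few compounds are considered here, and "the series" means these few. Any claim that something is new, unique, unknown or untested is made for them only; others in the source may bear on it.

Compound 1 `N#CC1=C(N)N(c2ccc(S(N)(=O)=O)cc2)C2=C(CCCC2)C1c1ccc([N+](=O)[O-])cc1` and compound 2 `N#CC1=C(N)N(c2ccc(S(N)(=O)=O)cc2)C2=C(CCCC2)C1c1ccc(Cl)c(Cl)c1` share one core and differ only in the group on a saturated ring carbon. In a functional assay on Ehrlich cells (Mus musculus) for cytotoxicity, read by trypan blue exclusion, with a stated time of 2 h (on this read-out higher numbers stand for weaker inhibition and lower numbers for stronger inhibition), compound 1 gives > 100 ug/mL, which is a limit of the assay rather than a number. In this assay, going by the values given here, compound 2 gives 100 ug/mL, the only number among the values shown. Among the compounds with values here, the single measured step, a number no higher from compound 1 to compound 2 (the limit leaves the size open), has a size that cannot be read due to the limit of > 100 ug/mL in this assay, at which 1 of the 2 values shown sits. Compound 3 `N#CC1=C(N)N(c2ccc(S(N)(=O)=O)cc2)C2=C(CCCC2)C1c1c(O)ccc2ccccc12` differs from compound 2 by 2-hydroxynaphthalen-1-yl in place of 3,4-dichlorophenyl on a saturated ring carbon. Within the data shown here, no measured step resembles this change, so the step of no change at the digits printed from compound 2 to compound 3 (within the scatter) is expected to stay within the scatter. Compound 3 is estimated at 100 ug/mL, within 40 ug/mL to 250 ug/mL.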

Compound 3, half-maximal inhibitory concentration: 100 ug/mL
For compound 3 middle estimate and measured number coincide at the digits printed; low and high end bracket the measured number.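

Putting 2-hydroxynaphthalen-1-yl in place of 3,4-dichlorophenyl on the saturated ring carbon gives, in this assay, no change at the digits printed from compound 2 to compound 3 (within the scatter). This position therefore takes on a second six-membered aromatic ring and a hydrogen-bond donor, and the number stays the same. Compound 1 gives only a limit of the assay, not a number. The remaining step is a number no higher from compound 1 to compound 3 (the limit leaves the size open) and its size cannot be read, due to a limit: the limit of > 100 ug/mL in this assay, at which 1 of the 3 values shown sits.

All three groups shown here are aromatic. As far as these compounds go, whether an amine, a carboxylic acid or a longer alkyl chain on this carbon would lower the number remains open.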